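From chlorophenyl to ethoxyphenyl on a silent scaffold

The compounds below may be only part of what the source reports. "The series", "measured", "known", "first", "only" and "open" are said of these compounds alone.

Compound 1 `N#CC1=C(N)Oc2c(c3nc4ccccc4nc3c3ccccc23)C12C(=O)N(Cc1cnnn1-c1ccccc1Br)c1ccccc12` and compound 2 `N#CC1=C(N)Oc2c(N)cc3nc4ccccc4nc3c2C12C(=O)N(Cc1cnnn1-c1ccc(Cl)cc1)c1ccccc12` were both examined in a functional assay on HepG2 cells (Homo sapiens) for antiproliferative activity, read by MTT assay, with a stated time of 48 h; a lower number here means a stronger inhibitor, a higher number a weaker inhibitor. For compound 1 the result is only a limit, > 50000 nM. For compound 2 too only a limit is known, > 50000 nM. Compound 2 stands at the limit of > 50000 nM in this assay, at which 2 of the 2 values shown sit. Compound 3 `CCOc1ccccc1-n1nncc1CN1C(=O)C2(C(C#N)=C(N)Oc3c(N)cc4nc5ccccc5nc4c32)c2ccccc21` has not been measured; it differs from compound 2 by 2-ethoxyphenyl in place of 4-chlorophenyl on an aromatic nitrogen. Within the data shown here, no step between measured compounds is available, and the size of this change cannot be read from the data. The step of a number no higher from compound 2 to compound 3 (the limit leaves the size open) is expected to be none beyond the scatter. Compound 3 is estimated at 50000 nM, between 20000 nM and 120000 nM.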

Compound 3, half-maximal inhibitory concentration: 30500 nM
Estimate against measurement, compound 3: 1.6-fold (0.21 log units) above; low and high end bracket the measured number.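

In this assay, among these compounds, compound 3 gives 30500 nM, the first value in this set that is a number rather than a limit. Putting 2-ethoxyphenyl in place of 4-chlorophenyl on the aromatic nitrogen gives an at least 1.6-fold lower number from compound 2 to compound 3 (0.21 log units; that floor lies within the scatter). Only this floor is known, and the true size of the step stays open, because compound 2 rests on a limit: the limit of > 50000 nM in this assay, at which 2 of the 3 values shown sit.

The compounds shown leave open whether the step follows from gaining the ethoxy group or from losing the chlorine. They also leave open how a phenyl ring with neither group, or one carrying an amine, would read in this assay.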